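Curcumin-coumarin triazole series: thiophene for methoxyphenyl

This account rests on a few compounds, and the source may have more. Where it says the series, first, only, none or still open, it means among the compounds named here.

Measured so far:
Compound 1 `COc1ccccc1/C=C/C(=O)/C=C/c1ccc(OCc2cn(CCCCCOc3cc(=O)oc4ccccc34)nn2)c(OC)c1`: "not active" (no number reported)
Compound 2 `COc1ccc(/C=C/C(=O)/C=C/c2ccc(OCc3cn(CCOc4cc(=O)oc5ccccc45)nn3)c(OC)c2)cc1`: 15%

Two compounds share the coumarin-bearing triazole tether and the dienone core. In a functional assay on PC-3 cells (Homo sapiens) for inhibition, read by sulforhodamine B assay, with a stated time of 48 h, tested at 50 uM (a higher number here means more inhibition of growth at the concentration tested, a lower number less inhibition of growth), compound 1 is reported as "not active" (no number reported) with no number attached, so it cannot be placed on a scale. In this assay compound 2 gives 15%, a modest degree of growth inhibition at the single concentration tested, and it is the only number shown in the series; no comparison between compound 1 and compound 2 can be drawn from a reported word alone.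

Compound 3 `COc1cc(/C=C/C(=O)/C=C/c2cccs2)ccc1OCc1cn(CCOc2cc(=O)oc3ccccc23)nn1` differs from compound 2 in one place, on the aryl terminus of the dienone: thiophen-2-yl in place of 4-methoxyphenyl on a double-bonded chain carbon bound to a double-bonded chain carbon. Among the measured compounds shown here, no step between two measured compounds exists here to calibrate what such a change does in this assay, so the expectation rests on compound 2 and the change alone.

The step of no change at the digits printed from compound 2 to compound 3 (within the scatter) is expected to stay within the scatter of repeated measurements. Compound 3 is therefore expected to give about 15%, with a likely range of 3% to 30%.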

Compound 3, percent growth inhibition at one concentration: 12%
Beside the measured number, compound 3's estimate is 3 percentage points above it; the measured number falls inside the stated range.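

In this assay, among the compounds shown here, exchanging 4-methoxyphenyl for thiophen-2-yl gives a number 3 percentage points lower from compound 2 to compound 3 (within the scatter), the first step that can be read at this position. The aryl terminus of the dienone can therefore pass from a six-membered aromatic ring of carbon only, with 8 heavy atoms in the group, to a five-membered aromatic ring with 1 hetero atom, with 5 heavy atoms in the group, without a change that can be told from scatter. No available measurement bears on why compound 2 and compound 3 read alike.

On these data alone, whether a different kind of group at this position, such as a dimethylamino-substituted phenyl or a carboxylic acid-bearing phenyl, would move the read-out beyond the scatter remains open. As far as these compounds go, the effect of tether length also remains open, since compound 1 differs from compound 2 in more than one place and carries a word rather than a number, so that comparison cannot be read.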